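The compounds below may be only part of what the source reports. "The series", "measured", "known", "first", "only" and "open" are said of these compounds alone.

Compound 1, `O=C(O)c1cn(CCCCCc2ccccc2)c2ccc([N+](=O)[O-])cc12`: 32.3%
Compound 2, `O=C(O)c1cc2cc(S(=O)(=O)N(Cc3ccccc3)Cc3ccccc3)ccc2n1Cc1ccccc1`: 41%
Compound 3, `O=C(O)c1cc2cc(S(=O)(=O)NCc3ccccc3)ccc2n1Cc1ccccc1`: 42%

All three numbers come from an assay on cells (Oocyte) for inhibition of pannexin-1 (Mus musculus), read by voltage clamp, tested at 50 uM, in the presence of a further agent that is not named here; on this read-out lower numbers stand for less inhibition and higher numbers for more inhibition at the one concentration tested (going by the name of the read-out). Compound 3 shows the highest of the three, but neither of the other two is separated from it by more than the scatter: the step of a number 1 percentage points higher from compound 2 to compound 3 (within the scatter) is a small one, and compound 1 sits within the scatter of compound 3 as well, so no real ranking among the three can be read from these numbers.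

Compound 4, `NS(=O)(=O)c1ccc2c(c1)cc(C(=O)O)n2Cc1ccccc1`, is not yet measured. It differs from compound 3 in one place: hydrogen in place of benzyl on a sulfonamide nitrogen. For the measured compounds named here, the one measured step that bears on this is the step from compound 2 to compound 3, which is the same kind of change on the same sulfonamide nitrogen; it gave a number 1 percentage points higher from compound 2 to compound 3 (within the scatter). On that basis the second removal of a benzyl is expected to move the number little: the step of a number 2 percentage points lower from compound 3 to compound 4 (within the scatter) is estimated to stay within the scatter, with no direction worth claiming. Compound 4 is therefore expected to give 40% in this assay, with a range from 25% to 55%. The number of bearing steps is one, so this estimate rests on thin ground.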

Compound 4, a percentage reported as inhibition, at one concentration (the size of the read-out at that concentration, not a potency): 29.3%
Beside the measured number, compound 4's estimate is 10.7 percentage points above it; measured number inside the range.
By their numbers in this assay, from the lowest: compounds 4, 1, 2 and 3 (each within the scatter of the next, the first and the last beyond it).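

In this assay, hydrogen in place of benzyl on the sulfonamide nitrogen gives a number 12.7 percentage points lower from compound 3 to compound 4 (beyond the scatter), whereas the same change with a second benzyl remaining on that nitrogen gives a number 1 percentage points higher from compound 2 to compound 3 (within the scatter). This position is therefore not indifferent to the change: across these two steps, one benzyl on the nitrogen is enough to keep the number within the scatter of the dibenzyl compound, and only the loss of the last benzyl produces a step beyond the scatter. No measurement on hand accounts for this difference between the two steps.

The compounds shown leave open whether any carbon group on that nitrogen would hold the number at the level of compound 3, or whether the benzyl is needed specifically; a methyl, a phenethyl or a cyclohexylmethyl group in its place would separate these possibilities. From the compounds shown here alone, the numbers also come from one concentration in this assay, so how the step from compound 3 to compound 4 would appear as a difference in potency remains open.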